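The source may report more compounds than this note shows. Statements on the series, on what has been measured and on what is new or still open speak of the compounds shown alone.

In an ADME assay on the whole organism with Sus scrofa as the target (on this read-out higher numbers stand for a longer-lived compound and lower numbers for a shorter-lived compound), compound 1 `CCCOc1oc(=O)c2cc(NC(=O)CC(C)C)ccc2c1Cl` gives 16 h. Going by the values given here, the only other measured compound, compound 2 `CCCOc1oc(=O)c2cc(NC(=O)[C@@H](NC(=O)OC(C)(C)C)C(C)C)ccc2c1Cl`, gives 17 h, so compound 1 stands level with it within the scatter, and neither can be ranked above the other. Compound 3 `CCCOc1oc(=O)c2cc(NC(=O)NCC)ccc2c1Cl` keeps the shared core and differs from compound 1 as follows: ethylamino in place of isobutyl on a carbonyl carbon. In words, ethylamino takes the place of isobutyl on a carbonyl carbon, turning (isobutylcarbonyl)amino into (ethylcarbamoyl)amino. Among the compounds with values here, only one measured step bears on this change: a 1.1-fold higher number from compound 1 to compound 2 (0.03 log units; within the scatter). It alters the same isobutyl-bearing chain, on a saturated chain carbon bound to a carbonyl carbon, yet stays within the scatter. Within the data shown here, it is only indirect evidence, since no measured compound carries ethylamino. On the strength of that single step, no change beyond the scatter is expected in this assay, and no direction can be favoured. The expected step is a 1.1-fold lower number from compound 1 to compound 3 (0.03 log units; within the scatter), which is a small one. For compound 3 the estimated half-life is 15 h, with an expected range from 8 h to 28 h.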

Compound 3, half-life: > 48 h
Compound 3 was reported as a limit; the forecaster's own chance of this, stated with the estimate: 2%; middle value at least 3.2-fold (0.50 log units) from the limit.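

In this assay, the carbonyl carbon proves to be a sensitive place in a way the earlier pair gave no sign of: ethylamino, which brings a nitrogen and a hydrogen-bond donor that isobutyl lacks, gives an at least 3.0-fold higher number from compound 1 to compound 3 (0.47 log units; beyond the scatter), whereas the change on the saturated chain carbon bound to that carbonyl carbon gave only a 1.1-fold higher number from compound 1 to compound 2 (0.03 log units; within the scatter). For compound 3, the value of > 48 h is a limit of the assay and not a number. The full size of the step from (isobutylcarbonyl)amino to (ethylcarbamoyl)amino therefore remains unknown because the reading for compound 3 stops at that limit: the limit of > 48 h in this assay, at which 1 of the 3 values shown sits.

This single pair cannot say whether the difference belongs to the nitrogen on the carbonyl carbon or to the shorter chain, as the two change together. From the compounds shown here alone, an ethoxy group on the same carbonyl carbon would test the nitrogen, a propylamino group would test the chain, and a dimethylamino group would test the amide-type hydrogen of the entering group, so all three questions remain open here.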